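This account rests on a few compounds, and the source may have more. Where it says the series, first, only, none or still open, it means among the compounds named here.

In a physicochemical assay for solubility, read by HPLC, in phosphate buffer, measured as kinetic solubility, at pH 7.4 (on this read-out higher numbers stand for higher solubility and lower numbers for lower solubility), compound 1 `CCC(=O)c1cc(-c2ccc(Cl)cc2)n(-c2ccc(S(=O)(=O)N(C)C)cc2)c1C` gives 1200 nM and compound 2 `CCOC(=O)c1cc(-c2ccc(OC)cc2)n(-c2ccc(S(N)(=O)=O)cc2)c1C` gives 16100 nM as its reading. Compound 3 `CC(C)(C)C(=O)c1cc(-c2ccc(S(N)(=O)=O)cc2)n(-c2ccc(Cl)cc2)n1` reads 6600 nM on the same test, which makes it the second highest of the three. Compound 2 lies above it and compound 1 below it, and both gaps are beyond the usual scatter of repeat measurements.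

The next compound, compound 4 `NS(=O)(=O)c1ccc(-c2cc(C(=O)CC3CCCC3)nn2-c2ccc(Cl)cc2)cc1`, keeps the rest of compound 3 and changes one group, with cyclopentylmethyl in place of tert-butyl on a carbonyl carbon. The three measured compounds differ from each other in more than one place, so none of them shows what this single change does. The expectation is therefore loose: a modest fall in this assay seems likely, and a result within the scatter would be no surprise. The expected move is a 1.9-fold lower number from compound 3 to compound 4 (0.28 log units; within the scatter) as a rough estimate. For compound 4 the estimate is 3500 nM with an expected range from 1000 nM to 9000 nM on this test.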

Compound 4, solubility: 2600 nM
For compound 4 the middle estimate is 1.3-fold (0.13 log units) above the measured one; measured number inside the range.
By their numbers in this assay, from the lowest: compound 1; then compound 4; then compound 3; then compound 2.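

In this assay, putting cyclopentylmethyl in place of tert-butyl on a carbonyl carbon gives a 2.5-fold lower number from compound 3 to compound 4 (0.40 log units; beyond the scatter) and so a modest step beyond the scatter. Going by these compounds alone, this is the first comparison in the set that differs in one place only, so it shows that this position alone can move the reading while the rest of compound 3 stays fixed. The entering group has more heavy atoms and brings a five-membered non-aromatic ring, but this single pair cannot separate the effect of the ring from that of the atom count, and no supporting measurement explains the step.

Open questions remain about how an open chain such as n-hexyl, or a chain ending in an amine or a carboxylic acid, would read at this position. It is also unknown whether the same exchange would give a similar step on the core of compound 1 or compound 2.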